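The source may hold more compounds than are shown below. What is called first, only, known or untested is meant among the compounds shown, and "the series" means these compounds.

Working notes on the series in a functional assay on the whole organism (strain albino) for inhibition, with Rattus norvegicus as the target, read by paw edema, with a stated time of 3 h, at a dose of 0.28 mmol/kg by the oral route; on this read-out higher numbers stand for more inhibition at the one dose given (going by the name of the read-out) and lower numbers for less inhibition.

Compound 1, `C=CCn1c(SCC(=O)c2ccccc2)nnc1-c1ccccc1`, gives 70% in this assay. Compound 2, `C=CCn1c(SCC(=O)c2ccccc2)nnc1-c1ccc(OC)c(OC)c1`, gives 64%. Compound 3, `C=CCn1c(SC/C(=N/O)c2ccccc2)nnc1-c1ccc(OC)cc1`, gives 67%. On these three numbers compound 3 stands second highest; its nearest neighbour is compound 1 and the furthest is compound 2, both gaps within the usual scatter, so the three compounds cannot be ordered against one another.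

Compound 4 is `C=CCn1c(SCC(=O)c2ccccc2)nnc1-c1ccc(OC)cc1`. Its change against compound 3 is a group of 8 heavy atoms (7 carbon, 1 oxygen; one six-membered aromatic ring of carbon only) in place of a group of 9 heavy atoms (7 carbon, 1 nitrogen, 1 oxygen; one six-membered aromatic ring of carbon only), on a saturated chain carbon bound to a sulfur. The group that enters is the one carried at the same place by compound 1 and compound 2, and those two compounds sit within the scatter of compound 3. Among the measured compounds shown here, no step between measured compounds is available to calibrate this change, so no movement beyond the scatter is expected in this assay, in either direction, and the step from compound 3 to compound 4 is estimated at no change at the digits printed from compound 3 to compound 4 (within the scatter). Compound 4 is expected to give 67%, within a range from 58% to 76%.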

Compound 4, a percentage reported as inhibition, in the whole organism at one dose (the size of the read-out at that dose, not a potency): 63%
Beside the measured number, compound 4's estimate is 4 percentage points above it, within the range that was stated.
By their numbers in this assay, from the lowest: compounds 4, 2, 3 and 1 (each within the scatter of the next).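

In this assay the benzoyl group in place of the nitrogen-bearing group on a saturated chain carbon bound to a sulfur gives a number 4 percentage points lower from compound 3 to compound 4 (within the scatter) and so offers no separation between the two groups at this place. On the aromatic carbon, hydrogen in place of methoxy gives a number 1 percentage points lower from compound 2 to compound 4 (within the scatter) and methoxy in place of hydrogen gives a number 7 percentage points lower from compound 1 to compound 4 (within the scatter); these steps leave the methoxy groups of compounds 1, 2 and 4 unseparated at the one dose given. Nothing at hand bears on the cause of these steps.

As far as these compounds go, whether a carboxylic acid or an amine on the saturated chain carbon bound to a sulfur would leave the scatter stays open. So does the effect of a chlorine on the aromatic carbon, and with one dose only the potency of these compounds also remains unknown.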